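The compounds below may be only part of what the source reports. "The series", "measured", "known", "first", "only" and "open" are said of these compounds alone.

Measured compounds in a functional assay on HT-29 cells (Homo sapiens) for antiproliferative activity, read by sulforhodamine B assay, with a stated time of 48 h; on this read-out higher numbers stand for weaker inhibition and lower numbers for stronger inhibition:
Compound 1 `CC(=O)Nc1ccc(S(=O)(=O)Oc2ccccc2C(C)C)cc1` gives 23000 nM in this assay.
Compound 2 `CCCC(=O)Nc1ccc(S(=O)(=O)Oc2ccccc2C(C)C)cc1` gives 4900 nM in this assay.
Compound 3 `CCCC(=O)Nc1ccc(S(=O)(=O)Oc2ccccc2I)cc1` gives 11000 nM in this assay.

Compound 3 stands second highest of the three numbers, with compound 1 nearest and compound 2 furthest; the step of a 2.2-fold higher number from compound 2 to compound 3 (0.35 log units; beyond the scatter) shows the gap to compound 2. Compound 4 `O=C(CCl)Nc1ccc(S(=O)(=O)Oc2ccccc2I)cc1` differs from compound 3 by chloro in place of ethyl on a saturated chain carbon bound to a carbonyl carbon. Within the data shown here, the only measured step at this place is a 4.7-fold lower number from compound 1 to compound 2 (0.67 log units; beyond the scatter), which shows that lengthening the chain bound to the carbonyl carbon lowered the number; shortening it in compound 4 runs the other way, so a somewhat higher number is expected in this assay. Among the measured compounds shown here, no measured step speaks to chloro at this position, so the range has to be wide. For compound 4 the estimate is 15000 nM, with a range from 3500 nM to 50000 nM. The expected step from compound 3 to compound 4 is a 1.4-fold higher number from compound 3 to compound 4 (0.13 log units; within the scatter).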

Compound 4, half-maximal inhibitory concentration: 4100 nM
Compound 4: middle estimate off by 3.7-fold (0.56 log units), on the high side; low and high end bracket the measured number.
By their numbers in this assay, from the lowest: compounds 4 and 2 (each within the scatter of the next); then compound 3; then compound 1.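

In this assay, replacing ethyl with chloro on the saturated chain carbon bound to the carbonyl carbon gave a 2.7-fold lower number from compound 3 to compound 4 (0.43 log units; beyond the scatter) in a compound that also carries iodo. Thus a shorter group at this place can still lower the number, whereas the earlier step of a 4.7-fold lower number from compound 1 to compound 2 (0.67 log units; beyond the scatter) had come with a longer chain, so chain length alone does not order the numbers here. The compounds shown give no reason for the effect of chloro at this place.

From the compounds shown here alone, whether the lowering belongs to the chloro group or to the change in chain length remains open, and a bromo or methoxy group on the same carbon would bear on that. Going by these compounds, it is also open whether chloromethyl would lower the number to a similar extent with isopropyl in place of iodo.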